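Propyl on sulfur in two related naphthyl sugar ethers

The source may hold more compounds than are shown below. What is called first, only, known or untested is meant among the compounds shown, and "the series" means these compounds.

Of the compounds shown here, three have been tested in an ADME assay on HFL1 cells (Homo sapiens) for antiproliferative activity, read by crystal violet staining, with a stated time of 96 h; on this read-out higher numbers stand for an effect only at larger amounts of compound and lower numbers for an effect already at smaller amounts. Compound 1 `O[C@@H]1[C@@H](O)[C@H](Oc2ccc(S)c3ccccc23)OC[C@H]1O` gives 70 uM, compound 2 `O[C@@H]1[C@@H](O)[C@H](Oc2cccc3c(S)cccc23)OC[C@H]1O` gives 60 uM, and compound 3 `CCCSc1ccc(O[C@@H]2OC[C@@H](O)[C@H](O)[C@H]2O)c2ccccc12` gives 30 uM. Compound 3 differs from compound 1 by one change, (propyl in place of hydrogen on a sulfur), and this change made the step of a 2.3-fold lower number from compound 1 to compound 3 (0.37 log units; beyond the scatter). How the cores of compound 1 and compound 2 differ is not broken down here; their two numbers lie within the scatter of each other. Compound 4 `CCCSc1cccc2c(O[C@@H]3OC[C@@H](O)[C@H](O)[C@H]3O)cccc12` is not yet measured. It differs from compound 2 by propyl in place of hydrogen on a sulfur, the same change as from compound 1 to compound 3. Because compound 3 gives 30 uM after this change, a step of similar size is expected in this assay, namely a 2.2-fold lower number from compound 2 to compound 4 (0.35 log units; beyond the scatter). Compound 4 is therefore estimated at 27 uM, between 13 uM and 55 uM.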

Compound 4, concentration for half-maximal effect: 20 uM
Beside the measured number, compound 4's estimate is 1.4-fold (0.13 log units) above it; measured number inside the range.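

In this assay, putting propyl in place of hydrogen on the sulfur gives a 3.0-fold lower number from compound 2 to compound 4 (0.48 log units; beyond the scatter), and the change behaves alike on the two cores: the same change on two cores in this assay, a 2.3-fold lower number (0.37 log units; beyond the scatter) from compound 1 to compound 3 and a 3.0-fold lower number (0.48 log units; beyond the scatter) from compound 2 to compound 4, 1.3-fold (0.11 log units) apart, within the scatter of two such steps. Within this pair, then, the step carries over in direction and size, and the two steps cannot be told apart. For the compounds shown here, this rests on only two cores in a single assay, so it shows neither that the change would carry to other cores nor why the number falls.

The compounds shown carry only hydrogen or propyl on the sulfur. As far as these compounds go, what a methyl, a longer chain such as hexyl, or a chain bearing an amine would do there remains open.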